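A few compounds are considered here, and "the series" means these few. Any claim that something is new, unique, unknown or untested is made for them only; others in the source may bear on it.

Working notes on the series. Compound 1 `CCSc1n[nH]c(-n2[se]c3ccccc3c2=O)n1` is measured in a functional assay on A549 cells (Homo sapiens) for antiproliferative activity, read by CCK-8 assay, with a stated time of 48 h (on this read-out lower numbers stand for stronger inhibition and higher numbers for weaker inhibition), at 39600 nM. Compound 2 `O=c1c2ccccc2[se]n1-c1nc(SCc2ccc(F)cc2)n[nH]1` gives 36400 nM in the same assay, and the step of a 1.1-fold lower number from compound 1 to compound 2 (0.04 log units; within the scatter) leaves the two compounds within the scatter of each other. Compound 3 `CC(C)Sc1n[nH]c(-n2[se]c3ccccc3c2=O)n1` differs from compound 2 by isopropyl in place of 4-fluorobenzyl on a sulfur. Within the data shown here, the only step available on this sulfur, the one from compound 1 to compound 2, stayed within the scatter, so no step beyond the scatter is expected for compound 3, and its expected step is a 1.0-fold higher number from compound 2 to compound 3 (0.02 log units; within the scatter). Compound 3 is therefore estimated at 38000 nM, with a range from 15000 nM to 100000 nM.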

Compound 3, half-maximal inhibitory concentration: 36600 nM
Beside the measured number, compound 3's estimate is 1.0-fold (0.02 log units) above it; the measured number falls inside the stated range.
By their numbers in this assay, from the lowest: compounds 2, 3 and 1 (each within the scatter of the next).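

On the sulfur, a group of 3 heavy atoms with no ring reads like one of 8 heavy atoms carrying an aromatic ring in this assay, with a 1.0-fold higher number from compound 2 to compound 3 (0.00 log units; within the scatter). The extra methyl on the saturated chain carbon bound to a saturated chain carbon and a sulfur also leaves the read-out within the scatter, with a 1.1-fold lower number from compound 1 to compound 3 (0.03 log units; within the scatter). No supporting data bear on why these groups read alike.

On these data alone, whether an amine or a carboxylic acid on this sulfur chain would give a step beyond the scatter stays open. The compounds shown also vary only on this sulfur, leaving changes to the shared core open.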